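A few compounds are considered here, and "the series" means these few. Any claim that something is new, unique, unknown or untested is made for them only; others in the source may bear on it.

Measured in a functional assay on A-375 cells (Homo sapiens) for inhibition, read by CCK-8 assay, with a stated time of 72 h, tested at 2 uM; on this read-out lower numbers stand for less inhibition of growth and higher numbers for more inhibition of growth at the one concentration tested:
- compound 1 `Nc1ccccc1NC(=O)c1ccc(CSCCc2ccccc2)cc1`: 21.8%
- compound 2 `Nc1ccccc1NC(=O)c1ccc(CSc2ccc(Cl)cc2)cc1`: 25.3%

Not yet measured: compound 3 `Cc1cc(C)cc(SCc2ccc(C(=O)Nc3ccccc3N)cc2)c1`.

Within the data shown here, with only two compounds measured, compound 2, at 25.3%, cannot be told apart from compound 1, at 21.8%. In compound 3, the shared core is kept and one group changes: 3,5-dimethylphenyl in place of 4-chlorophenyl on a sulfur. The new aryl group, 3,5-dimethylphenyl, stays on the same sulfur.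

Among the measured compounds shown here, only one measured step bears on this change: a number 3.5 percentage points higher from compound 1 to compound 2 (within the scatter). There, 4-chlorophenyl took the place of phenethyl on a sulfur, a larger change of group than the one now at hand, and this assay still showed nothing beyond the scatter. For the measured compounds named here, this is thin evidence, since no measured compound carries methyl groups on the aryl ring, so the range must stay wide. No step beyond the scatter is expected, in either direction. The expected step is small: a number 0.7 percentage points higher from compound 2 to compound 3 (within the scatter).

For compound 3 the estimated value is 26%, with an expected range from 14% to 42%.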

Compound 3, percent growth inhibition at one concentration: 48.5%
For compound 3 the middle estimate is 22.5 percentage points below the measured one, outside the stated range (above it).
By their numbers in this assay, from the lowest: compounds 1 and 2 (each within the scatter of the next); then compound 3.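

In this assay, among these compounds, the group on the sulfur proves able to move the read-out: 3,5-dimethylphenyl in place of 4-chlorophenyl gives a number 23.2 percentage points higher from compound 2 to compound 3 (beyond the scatter), and 3,5-dimethylphenyl in place of phenethyl gives a number 26.7 percentage points higher from compound 1 to compound 3 (beyond the scatter), whereas the one earlier change at this place stayed within the scatter. The two aryl groups exchanged in the newer step are closely matched in what can be counted, each having one six-membered aromatic ring of carbon only, no hydrogen-bond donors or acceptors and no net charge, so a change that looks small on those counts can still separate two compounds here. Nothing available shows what lies behind this difference.

Among the compounds shown here, the single exchange removes the chlorine and adds two methyl groups at once, so it remains open whether a plain phenyl or a phenyl with a single methyl group on the same sulfur would read like compound 2 or like compound 3. Also open, as far as these compounds go, is how an amine or a carboxylic acid on that aryl ring would read in this assay.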